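A few compounds are considered here, and "the series" means these few. Any claim that something is new, unique, unknown or untested is made for them only; others in the source may bear on it.

Measured so far:
Compound 1 `CCOC(=O)C[C@H]1[C@@H](O[Si](C)(C)C(C)(C)C)[C@H](n2cnc3c(NC(=O)Nc4ccccc4)ncnc32)O[C@@H]1COC(=O)NC` gives 3.26 nM in a functional assay on MDA-MB-435 cells (Homo sapiens) for antiproliferative activity; a lower number here means a stronger inhibitor of growth, a higher number a weaker inhibitor of growth.
Compound 2 `CNC(=O)NC[C@H]1O[C@@H](n2cnc3c(NC(=O)Nc4ccccc4)ncnc32)[C@H](O[Si](C)(C)C(C)(C)C)[C@@H]1CC(=O)N(C)OC` gives 10.9 nM in this assay.

Of these two numbers, compound 2 carries the higher one, and its gap to compound 1 lies beyond the usual scatter of this assay, so compound 2 is the weaker growth inhibitor of the pair as measured.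

Compound 3 `CCOC(=O)C[C@H]1[C@@H](O[Si](C)(C)C(C)(C)C)[C@H](n2cnc3c(NC(=O)Nc4ccccc4)ncnc32)O[C@@H]1CNC(=O)NC` is not yet measured. It is reached from compound 2 by one change at the carbonyl carbon next to the saturated chain carbon: ethoxy in place of methoxy(methyl)amino on a carbonyl carbon. The ethoxy group that enters is the same group that compound 1 carries on its own carbonyl, while the rest of compound 3 follows compound 2.

Since compound 1 gives 3.26 nM and compound 2 gives 10.9 nM, a modest move toward a lower number is expected, a 1.8-fold lower number from compound 2 to compound 3 (0.26 log units; within the scatter), though it may fall within the scatter. Compound 3 is estimated at 6 nM, with a range from 2 nM to 18 nM.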

Compound 3, concentration for 50% growth inhibition: 6.21 nM
Beside the measured number, compound 3's estimate is 1.0-fold (0.01 log units) below it, and the stated range covers the measured number.
By their numbers in this assay, from the lowest: compounds 1, 3 and 2 (each within the scatter of the next, the first and the last beyond it).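

In this assay, ethoxy in place of methoxy(methyl)amino on a carbonyl carbon gives a 1.8-fold lower number from compound 2 to compound 3 (0.24 log units; within the scatter), so this assay does not tell these two groups apart at this position. For the compounds shown here, on the saturated chain carbon bound to a saturated ring carbon, (methylcarbamoyl)amino in place of (methylcarbamoyl)oxy gives a 1.9-fold higher number from compound 1 to compound 3 (0.28 log units; within the scatter), so neither single change goes beyond the scatter, and this is the first view of each change on its own. Nothing measured here offers a reason for either step.

As far as these compounds go, only ethoxy and methoxy(methyl)amino are seen on this carbonyl carbon, so it stays open whether a carboxylic acid, a primary amide or a longer alkoxy chain there would give a similar number in this assay. The same question stands for the other position, where an amine or a simple ether could take the place of the (methylcarbamoyl)amino group.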